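Swapping the aryl group on the semicarbazone of compound 2

This account rests on a few compounds, and the source may have more. Where it says the series, first, only, none or still open, it means among the compounds named here.

Of the compounds shown here, three share a core and have been tested in a functional assay on a cell-free system (plasma) for agonist activity at thromboxane A2 receptor (Homo sapiens); on this read-out lower numbers stand for stronger inhibition and higher numbers for weaker inhibition. Compound 1 `O=C(O)CC/C=C1/C[C@H]2C[C@@H](O)[C@H](/C=N/NC(=O)Nc3cccc(Cl)c3)[C@H]2C1` gives 600 nM. Compound 2 `O=C(O)COC/C=C1/C[C@H]2C[C@@H](O)[C@H](/C=N/NC(=O)Nc3cccc(Cl)c3)[C@H]2C1` gives 180 nM, and compound 3 `O=C(O)COC/C=C1\C[C@H]2C[C@@H](O)[C@H](/C=N/NC(=O)Nc3cccc(Cl)c3)[C@H]2C1` gives 1600 nM. Compound 2 has the lowest number of the three: a 3.3-fold lower number from compound 1 to compound 2 (0.52 log units; beyond the scatter), and an 8.9-fold higher number from compound 2 to compound 3 (0.95 log units; beyond the scatter), a step that rests only on geometry because of the fact that compounds 2 and 3 differ only in the configuration as drawn.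

Compound 4 `O=C(O)COC/C=C1/C[C@H]2C[C@@H](O)[C@H](/C=N/NC(=O)Nc3ccc([N+](=O)[O-])cc3)[C@H]2C1` differs from compound 2 in one place: 4-nitrophenyl in place of 3-chlorophenyl on an amide-type nitrogen. Neither measured step touches this part of the molecule; one changes the acid-bearing chain, the other the geometry of a double bond. Within the data shown here, no measured step therefore bears on this change, and the expectation is that the number for compound 4 stays close to that of compound 2, with no step beyond the scatter, though the range must stay wide. The estimate for compound 4 in this assay is 250 nM, between 70 nM and 900 nM. This means an expected step of a 1.4-fold higher number from compound 2 to compound 4 (0.14 log units; within the scatter).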

Compound 4, half-maximal inhibitory concentration: 20 nM
Compound 4: the middle estimate sits 13-fold (1.10 log units) above what was measured; the whole stated range lies above it.
By their numbers in this assay, from the lowest: compound 4; then compound 2; then compound 1; then compound 3.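

The aryl group on the amide-type nitrogen is not a silent part of these molecules: in this assay, replacing 3-chlorophenyl with 4-nitrophenyl gives a 9.0-fold lower number from compound 2 to compound 4 (0.95 log units; beyond the scatter), and compound 4 has the lowest number of the four compounds shown. So this end of the molecule can move the read-out as clearly as the acid-bearing chain and the double-bond geometry, the only two places the earlier compounds had varied. Nothing in the available evidence explains why this swap lowers the number.

The step changes two things at once, the atoms on the ring and their place on it, so it cannot say which one matters. A 4-chlorophenyl or a 3-nitrophenyl group on the same nitrogen would pull the two apart, and an unsubstituted phenyl would give a plain reference point.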